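The source may report more compounds than this note shows. Statements on the series, on what has been measured and on what is new or still open speak of the compounds shown alone.

Measured compounds in a functional assay on HEK293 cells for agonist activity at G-protein coupled receptor 39 (Homo sapiens), read by scintillation proximity assay and inositol phosphate accumulation, with a stated time of 75 min, in the presence of a further agent that is not named here; on this read-out higher numbers stand for an effect only at larger amounts of compound and lower numbers for an effect already at smaller amounts:
compound 1 `Cc1nn(-c2ncnc3nc[nH]c23)c2c1C(OC1CCCC1)CC(=O)N2` gives 2 nM
compound 2 `Cc1nn(-c2ncnc3nc[nH]c23)c2c1C(c1ccc(F)cc1Cl)CC(=O)N2` gives 9 nM
compound 3 `Cc1nn(-c2ncnc3nc[nH]c23)c2c1C(C(=O)Nc1ccccc1)CC(=O)N2` gives 10 nM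

Compound 1 stands lowest of the three numbers. The two measured exchanges at the same saturated ring carbon both moved the number upward: a 4.5-fold higher number from compound 1 to compound 2 (0.65 log units; beyond the scatter) and a 5.0-fold higher number from compound 1 to compound 3 (0.70 log units; beyond the scatter); between the two replacements the gap is a 1.1-fold higher number from compound 2 to compound 3 (0.05 log units; within the scatter), within scatter. Compound 4 `Cc1nn(-c2ncnc3nc[nH]c23)c2c1C(NC(=O)Cc1cccs1)CC(=O)N2` carries a third exchange at that carbon: (((thiophen-2-yl)methyl)carbonyl)amino in place of cyclopentyloxy on a saturated ring carbon. The entering group, like the phenylcarbamoyl of compound 3, brings an amide, and nothing measured suggests the replacement of cyclopentyloxy here is without cost. A modest rise of the same size is therefore expected for compound 4, roughly a 5.0-fold higher number from compound 1 to compound 4 (0.70 log units; beyond the scatter). For compound 4 in this assay the estimate is 10 nM, with a range of 3 nM to 40 nM.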

Compound 4, half-maximal effective concentration: 3 nM
For compound 4 the middle estimate is 3.3-fold (0.52 log units) above the measured one; low and high end bracket the measured number.
By their numbers in this assay, from the lowest: compounds 1 and 4 (each within the scatter of the next); then compounds 2 and 3 (each within the scatter of the next).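

The step of a 1.5-fold higher number from compound 1 to compound 4 (0.18 log units; within the scatter) shows that this saturated ring carbon can take (((thiophen-2-yl)methyl)carbonyl)amino in place of cyclopentyloxy without a change beyond the scatter, so the low end of the series is not tied to cyclopentyloxy. An amide at this carbon does not set the number by itself, as the steps of a 3.3-fold lower number from compound 3 to compound 4 (0.52 log units; beyond the scatter) and of a 3.0-fold lower number from compound 2 to compound 4 (0.48 log units; beyond the scatter) both separate the new group from the earlier replacements. Nothing available accounts for these differences.

Still open, from the compounds shown here alone, is how a free amine or a carboxylic acid on this carbon would read. Also open, going by these compounds, is whether a phenyl ring in place of the thiophene of compound 4 would keep its number.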